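The compounds below may be only part of what the source reports. "The series", "measured", "known", "first", "only" and "open" are said of these compounds alone.

Measured compounds:
compound 1 `COc1ccc(C(=O)/C=C/c2cc(-c3cc(OC)c(OC)c(OC)c3)n3nc(-c4ccccc4)cc3n2)cc1OC` — 17800 nM
compound 2 `COc1cc(-c2cc(/C=C/C(=O)c3ccc(C)c(C)c3)nc3cc(-c4ccccc4)nn23)cc(OC)c1OC` — 10600 nM
compound 3 `COc1cc(C(=O)/C=C/c2cc(-c3cc(OC)c(OC)c(OC)c3)n3nc(-c4ccccc4)cc3n2)cc(OC)c1OC` — 20500 nM

In a functional assay on A549 cells (Homo sapiens) for antiproliferative activity, read by MTT assay, with a stated time of 24 h (on this read-out higher numbers stand for weaker inhibition and lower numbers for stronger inhibition), compound 2 gives the lowest of the three numbers, but its steps to the others, a 1.7-fold lower number from compound 1 to compound 2 (0.23 log units; within the scatter) and a 1.9-fold higher number from compound 2 to compound 3 (0.29 log units; within the scatter), both lie within the scatter, so no ordering among the three can be read from them. Compound 4 `COc1ccc(/C=C/C(=O)c2cc(-c3cc(OC)c(OC)c(OC)c3)n3nc(-c4ccccc4)cc3n2)cc1` differs from compound 2 at one place: (2-(4-methoxyphenyl)ethenyl)carbonyl in place of 2-((3,4-dimethylphenyl)carbonyl)ethenyl on an aromatic carbon. Among the measured compounds shown here, the steps that touch the same region, a 1.7-fold lower number from compound 1 to compound 2 (0.23 log units; within the scatter) and a 1.9-fold higher number from compound 2 to compound 3 (0.29 log units; within the scatter), stayed within the scatter, and no measured pair tests the swap of the carbonyl and ethenyl order itself. From these, the step in this assay from compound 2 to compound 4 is expected to be small, a 1.3-fold higher number from compound 2 to compound 4 (0.12 log units; within the scatter). Compound 4 is estimated at 14000 nM, within 6000 nM to 35000 nM.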

Compound 4, half-maximal inhibitory concentration: 21200 nM
For compound 4 the middle estimate is 1.5-fold (0.18 log units) below the measured one; low and high end bracket the measured number.
By their numbers in this assay, from the lowest: compounds 2, 1, 3 and 4 (each within the scatter of the next).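

In this assay, among the compounds shown here, the step to (2-(4-methoxyphenyl)ethenyl)carbonyl in place of 2-((3,4-dimethylphenyl)carbonyl)ethenyl is a 2.0-fold higher number from compound 2 to compound 4 (0.30 log units; within the scatter) and is the first here to swap the carbonyl and ethenyl order at this aromatic carbon. Even this swap, made together with a new set of groups on the outer ring, stays within the scatter. The two parts of the change cannot be separated, since they arrive together in compound 4.

As far as these compounds go, whether an amine or a carboxylic acid on that outer ring would give a number beyond the scatter remains open. No measured finding accounts for these numbers.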